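Methyl on the pendant phenyl across two related cores

This account rests on a few compounds, and the source may have more. Where it says the series, first, only, none or still open, it means among the compounds named here.

Compound 1 `Cc1[nH]c2ccccc2c1C1=C(Br)C(=O)C(c2c(-c3ccccc3)[nH]c3ccccc23)=C(Br)C1=O` and compound 2 `Cc1ccc(-c2[nH]c3ccccc3c2C2=C(Br)C(=O)C(c3c(C)[nH]c4ccccc34)=C(Br)C2=O)cc1` share one core; compound 3 `Cc1[nH]c2ccccc2c1C1=C(Br)C(=O)C(Br)=C(c2c(-c3ccccc3)[nH]c3ccccc23)C1=O` and compound 4 `Cc1ccc(-c2[nH]c3ccccc3c2C2=C(Br)C(=O)C(Br)=C(c3c(C)[nH]c4ccccc34)C2=O)cc1` share another, and the difference between the two cores is not broken down here. In a functional assay on MDA-MB-231 cells (Homo sapiens) for antiproliferative activity, read by CCK-8 assay, with a stated time of 48 h (on this read-out higher numbers stand for weaker inhibition and lower numbers for stronger inhibition), compound 1 gives 5.64 ug/mL and compound 2 gives 6.67 ug/mL, while compound 3 gives 4.33 ug/mL. The change between the measured pair is methyl in place of hydrogen on an aromatic carbon, and the step it made is a 1.2-fold higher number from compound 1 to compound 2 (0.07 log units; within the scatter). The change from compound 3 to compound 4 is methyl in place of hydrogen on an aromatic carbon, the same change at the same place. For compound 4 in this assay a step of a 1.2-fold higher number from compound 3 to compound 4 (0.08 log units; within the scatter) is expected, because a 1.2-fold higher number from compound 1 to compound 2 (0.07 log units; within the scatter) was all this change produced on the other core. The estimate for compound 4 is 5.2 ug/mL, expected to fall between 3 ug/mL and 9 ug/mL.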

Compound 4, half-maximal inhibitory concentration: 5.89 ug/mL
Beside the measured number, compound 4's estimate is 1.1-fold (0.05 log units) below it; measured number inside the range.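

Phenyl to 4-methylphenyl on the second core, in this assay, gives a 1.4-fold higher number from compound 3 to compound 4 (0.13 log units; within the scatter). The steps on the two cores agree: the same change on two cores in this assay, a 1.2-fold higher number (0.07 log units; within the scatter) from compound 1 to compound 2 and a 1.4-fold higher number (0.13 log units; within the scatter) from compound 3 to compound 4, 1.2-fold (0.06 log units) apart, within the scatter of two such steps. This shows that the methyl swap behaves alike on these two cores, but both steps lie within the scatter and each core supplies a single pair, so it does not show that a step large enough to read would carry from one core to the other.

Open, from the compounds shown here alone, is whether an amine, a carboxylic acid or a longer chain in place of methyl on the phenyl would give a step beyond the scatter. Also open, going by these compounds, is whether such a step would repeat on the other core.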